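Shifting the Chlorine on the Ring: Compound 3 to Compound 4

The source may report more compounds than this note shows. Statements on the series, on what has been measured and on what is new or still open speak of the compounds shown alone.

Three compounds with a shared core, each bearing a different aromatic ring on a carbon with a double bond to nitrogen, have been tested in a functional assay on HT-29 cells (Homo sapiens) for inhibition, read by sulforhodamine B assay, with a stated time of 48 h; a higher number here means a weaker inhibitor of growth, a lower number a stronger inhibitor of growth. Compound 1 `CC1=CC[C@H](C(C)(C)NC(=S)N/N=C/c2ccc(O)cc2)CC1` carries a 4-hydroxyphenyl, and its result in this assay is a limit of the assay, > 100000 nM. Compound 2 `CC1=CC[C@H](C(C)(C)NC(=S)N/N=C/c2ccc(N(C)C)cc2)CC1` has a dimethylamino in place of the hydroxy and gives 46500 nM in this assay, a step of an at least 2.1-fold lower number from compound 1 to compound 2 (0.33 log units; beyond the scatter). Compound 3 `CC1=CC[C@H](C(C)(C)NC(=S)N/N=C/c2cccc(Cl)c2)CC1` carries a 3-chlorophenyl and gives 7900 nM in this assay, the lowest of the two numbers, with compound 2 as the nearest, after a step of an at least 12-fold lower number from compound 1 to compound 3 (1.10 log units; beyond the scatter).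

Compound 4 `CC1=CC[C@H](C(C)(C)NC(=S)N/N=C/c2ccc(Cl)cc2)CC1` has not yet been measured; it differs from compound 3 by 4-chlorophenyl in place of 3-chlorophenyl on a carbon with a double bond to nitrogen. Going by the values given here, no measured step exchanges a 3-chlorophenyl for a 4-chlorophenyl; both measured steps replace the 4-hydroxyphenyl of compound 1 and bear only loosely on this change. Compound 4 is therefore expected to stay close to compound 3, with the step of a 1.0-fold higher number from compound 3 to compound 4 (0.01 log units; within the scatter) expected to be small. Compound 4 is estimated at 8000 nM, within a range from 2500 nM to 25000 nM.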

Compound 4, concentration for 50% growth inhibition: 13600 nM
The estimate for compound 4 lay 1.7-fold (0.23 log units) below the measured number, within the range that was stated.
By their numbers in this assay, from the lowest: compounds 3 and 4 (each within the scatter of the next); then compound 2. At a limit, above all of these: compound 1.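

In this assay the 3-chlorophenyl and the 4-chlorophenyl cannot be told apart, with a 1.7-fold higher number from compound 3 to compound 4 (0.24 log units; within the scatter), so the two chlorine placements give a single reading here. Compound 4 also allows a one-group comparison on an aromatic carbon, where chloro in place of dimethylamino gives a 3.4-fold lower number from compound 2 to compound 4 (0.53 log units; beyond the scatter). Chloro in place of hydroxy gives an at least 7.3-fold lower number from compound 1 to compound 4 (0.86 log units; beyond the scatter), a step that can be stated only as a bound because compound 1 stands at a limit of the assay: the limit of > 100000 nM in this assay, at which 1 of the 4 values shown sits.

Still open, as far as these compounds go, is how a bromo, a nitrile or a carboxylic acid on the aromatic ring would read in this assay. The compounds shown also do not tell whether the two chlorine placements would still read alike with a longer chain on the shared core.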